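Trifluoromethyl to hydrogen across two related cores

The source may hold more compounds than are shown below. What is called first, only, known or untested is meant among the compounds shown, and "the series" means these compounds.

Measured so far:
compound 1 `O=c1oc2ccccc2n1CCN1CCN(c2cccc(C(F)(F)F)c2)CC1`, a functional assay on the whole organism with Mus musculus as the target; a higher number here means that more compound is needed for the effect, a lower number that less compound is needed: 30.2 mg/kg
compound 2 `O=c1oc2cccnc2n1CCCN1CCN(c2ccccc2)CC1`, this assay: 15.5 mg/kg
compound 3 `O=c1oc2cccnc2n1CCCN1CCN(c2cccc(C(F)(F)F)c2)CC1`, this assay: 22 mg/kg

Compound 1 carries the highest of the three numbers; against compound 3 it differs by a 1.4-fold lower number from compound 3 to compound 2 (0.15 log units; within the scatter) in the opposite direction only in size, and against compound 2 the gap is also within the scatter, so no ordering among the three is claimed. The difference between the core of compound 1 and the core of compound 3 is not broken down here.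

Within the core of compound 3, one change is measured: hydrogen in place of trifluoromethyl on an aromatic carbon, giving a 1.4-fold lower number from compound 3 to compound 2 (0.15 log units; within the scatter). This is a step inside the scatter, so compounds 3 and 2 are read as equivalent in this assay.

Compound 4 `O=c1oc2ccccc2n1CCN1CCN(c2ccccc2)CC1` is not yet measured. It stands to compound 1 as compound 2 stands to compound 3: hydrogen in place of trifluoromethyl on an aromatic carbon. The place lines of the two changes agree word for word, so it is the same change on a different core. The expectation for compound 4 rests on a single precedent, the step from compound 3 to compound 2 of a 1.4-fold lower number from compound 3 to compound 2 (0.15 log units; within the scatter), and on the starting value of compound 1 at 30.2 mg/kg; a step of a 1.4-fold lower number from compound 1 to compound 4 (0.14 log units; within the scatter) is expected, again within the scatter. Going by the values given here, compound 4 is accordingly estimated at 22 mg/kg, with a likely range from 11 mg/kg to 44 mg/kg, the width reflecting that only one pair supports the transfer.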

Compound 4, dose for half-maximal effect: > 50 mg/kg
Compound 4: only a limit was reported (the forecaster's own chance of this, stated with the estimate: 5%); middle value at least 2.2-fold (0.35 log units) away from the limit.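

Compound 4 is reported in this assay only as a limit, > 50 mg/kg, and this is not a measured number. Hydrogen in place of trifluoromethyl on the core of compound 1 gives an at least 1.6-fold higher number from compound 1 to compound 4 (0.21 log units; that floor lies within the scatter), so this step has a floor but no known size, and the floor alone does not separate the two compounds. With only two pairs, neither a clean carry-over of this change between cores nor a dependence on the core is established, and the comparison stands as follows: the same change on two cores in this assay, a 1.4-fold lower number (0.15 log units; within the scatter) from compound 3 to compound 2 and an at least 1.6-fold higher number (0.21 log units; that floor lies within the scatter) from compound 1 to compound 4; the limit leaves it open whether they differ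

Compound 1 and compound 3 differ in more than one place, so the compounds shown do not separate the effect of the core from that of the chain length, and a longer chain on the core of compound 1 would address this directly. Also open, on these data alone, is how a chlorine, a methoxy group or a nitrile would compare with trifluoromethyl and hydrogen on that aromatic carbon, on either core, and a value for compound 4 beyond its limit would be needed before the two steps could be compared in size.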